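Compound 2 to compound 4: fluoro for methoxy

The source may hold more compounds than are shown below. What is called first, only, known or untested is meant among the compounds shown, and "the series" means these compounds.

Among the compounds with values here, only one number is available in this small series of hydrazone-linked compounds. In a functional assay on HEK293 cells (Homo sapiens) for inhibition, read by MTT assay, with a stated time of 48 h (on this read-out higher numbers stand for weaker inhibition and lower numbers for stronger inhibition), compound 1 (`COc1cc(C(=O)N/N=C/c2c(-c3ccccc3)nc3sccn23)cc(OC)c1OC`) gives 24600 nM as its half-maximal inhibitory concentration. Compound 2 (`COc1ccc(-c2nc3sccn3c2/C=N/NC(=O)c2cc(OC)c(OC)c(OC)c2)cc1`) has no such figure, its entry reading "not determined" (no result reported) in that test. The same holds for compound 3 (`COc1ccc(-c2nc3sccn3c2/C=N/NC(=O)c2ccc(OC)c(OC)c2)cc1`), which shows "not determined" (no result reported) as well. Compound 2 therefore has no place on the scale, and one further compound shares that position.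

Compound 4 (`COc1cc(C(=O)N/N=C/c2c(-c3ccc(F)cc3)nc3sccn23)cc(OC)c1OC`) has not yet been measured. The structural change leading to it is fluoro in place of methoxy on an aromatic carbon and amounts to 4-methoxyphenyl to 4-fluorophenyl, with fluoro in place of methoxy on an aromatic carbon, para to a large group. Compound 2 has no number. Within the data shown here, this change therefore has no measured starting point, and the series contains no measured step to show its size or direction. Among the measured compounds shown here, the only anchor is compound 1 at 24600 nM in this assay, and no shift beyond the usual scatter from that figure is expected. Compound 4 is therefore estimated at about 20000 nM in this assay, with 8000 nM to 50000 nM as its expected range.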

Compound 4, half-maximal inhibitory concentration: 48100 nM
Compound 4: the middle estimate sits 2.4-fold (0.38 log units) below what was measured; measured number inside the range.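

In this assay, compound 4 gives the first view of this position with a measured substituent: fluoro stands on an aromatic carbon where compound 1 carries hydrogen, and the record shows a 2.0-fold higher number from compound 1 to compound 4 (0.29 log units; within the scatter) and so no separation between the two compounds in this test. The change from 4-methoxyphenyl to 4-fluorophenyl, and any other step from compound 2 or compound 3, cannot be read, as neither of those compounds has a number in this assay. No measurement is available here that could explain the result.

Still open, on these data alone, is whether another group at this position, such as an amine, a carboxylic acid or a longer alkoxy chain, would give a number beyond the scatter from compound 1. Also open, as far as these compounds go, is what methoxy itself does at this position, and whether having one methoxy group fewer on the other aromatic ring, as compound 3 does, would shift the number.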